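The compounds below may be only part of what the source reports. "The series", "measured", "known", "first", "only" and "open" are said of these compounds alone.

Compound 1 `O=C(Nc1ccc(Cl)c(-c2nnc3c(Cl)cccn23)c1)c1ccc(Cl)cc1` carries an amide that links the shared core to a 4-chlorophenyl carbonyl group. In a functional assay on U-251 cells (Homo sapiens) for antiproliferative activity, read by MTT assay, with a stated time of 72 h (on this read-out lower numbers stand for stronger inhibition and higher numbers for weaker inhibition), compound 1 gives > 100000 nM, which is a limit of the assay rather than a number. Compound 2 `O=C(Nc1ccc(Cl)c(-c2nnc3c(Cl)cccn23)c1)c1ccc(C(F)(F)F)cc1F` also stops at a limit in this assay, giving > 100000 nM. Among the measured compounds shown here, compound 3 `CS(=O)(=O)c1ccc(C(=O)Nc2ccc(Cl)c(-c3nnc4c(Cl)cccn34)c2)c(Cl)c1` gives 44600 nM in this assay, the only true number among the three. Compound 1 thus sits at the limit of > 100000 nM in this assay, at which 2 of the 3 values shown sit. Compound 4 `O=C(Nc1ccc(Cl)c(-c2nnc3c(Cl)cccn23)c1)c1cccnc1Cl` differs from compound 1 by 2-chloropyridin-3-yl in place of 4-chlorophenyl on a carbonyl carbon. For the measured compounds named here, no measured step between compounds differing in one place exists here, so the change is expected to leave compound 4 close to where it stands, the step being estimated as a number no higher from compound 1 to compound 4 (the limit leaves the size open). Compound 4 is therefore estimated at 100000 nM, within 40000 nM to 300000 nM, most likely again as a limit.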

Compound 4, half-maximal inhibitory concentration: > 100000 nM
Compound 4 gave a limit, no number; the forecaster's own chance of this, stated with the estimate: 70%; the middle value sits exactly at the limit.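

Compound 1 and compound 4 both stop at a limit rather than a number, so no step between them can be read: the limit of > 100000 nM in this assay, at which 3 of the 4 values shown sit.

From the compounds shown here alone, whether 2-chloropyridin-3-yl in place of 4-chlorophenyl changes the antiproliferative activity at all remains open.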